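The compounds below may be only part of what the source reports. "The series", "measured", "known", "first", "only" and "open" are said of these compounds alone.

Within the data shown here, compound 1, `COc1ccc(OCCCON2C(N)=NC(N)=NC23CCOCC3)cc1`, is one of three compounds measured in an assay on isolated protein for inhibition of Dihydrofolate reductase (Homo sapiens), read by spectrophotometry, using NADPH, with stated times of 5 s and 6 min, tested at 5 uM; on this read-out higher numbers stand for a stronger effect at the one concentration tested and lower numbers for a weaker effect. In this assay compound 1 gives > 90%, which is a limit of the assay rather than a number. Compound 2, `NC1=NC2(CCOCC2)N(OCCCOc2ccc(Cl)c(Cl)c2)C(N)=N1`, gives > 90% in this assay, again a limit. Compound 3, `NC1=NC2(CCOCC2)N(OCCCOc2cc(Cl)c(Cl)cc2Cl)C(N)=N1`, gives > 90% in this assay, also a limit. All three values sit at the same limit, (the limit of > 90% in this assay, at which 3 of the 3 values shown sit), so the measured steps are a step that the two limits leave unreadable from compound 1 to compound 2, a step that the two limits leave unreadable from compound 1 to compound 3 and a step that the two limits leave unreadable from compound 2 to compound 3. The unmeasured compound 4, `CC(C)(C)c1ccc(OCCCON2C(N)=NC(N)=NC23CCOCC3)cc1`, differs from compound 1 in one place: tert-butyl in place of methoxy on an aromatic carbon. Among the measured compounds shown here, none of the measured steps concerns this particular change, and all three leave their size unreadable, so they can show only that varied substitution of the aromatic ring at the end of the chain kept each compound at the limit. Compound 4 is therefore expected to reach the same limit, with an estimated step that the limit leaves unreadable from compound 1 to compound 4. The estimate for compound 4 is 92%, between 85% and 99%.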

Compound 4, a percentage reported as inhibition, at one concentration (the size of the read-out at that concentration, not a potency): > 90%
Compound 4 ended at the assay's limit (the forecaster's own chance of this, stated with the estimate: 85%); the middle value is on the limit's open side.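

In this assay compound 4 gives > 90% as a limit of the assay, so no size can be read for its step from compound 1. Going by these compounds, how compound 1, compound 2, compound 3 and compound 4 rank against one another in this assay stays open, with all four at the same limit.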